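Stereochemistry at the limit of a cytotoxicity assay

The source may hold more compounds than are shown below. What is called first, only, known or untested is meant among the compounds shown, and "the series" means these compounds.

Compound 1 `CCOC(=O)[C@@]1(C(=O)Nc2ccccc2Cl)C[C@@H]1c1cc(OC)c(OC)c(OC)c1` gives > 100000 nM (a limit)
Compound 2 `CCOC(=O)[C@]1(C(=O)NCc2ccc(C)cc2)C[C@H]1c1cc(OC)c(OC)c(OC)c1` gives 28500 nM
Compound 3 `CCOC(=O)[C@]1(C(=O)Nc2ccccc2Cl)C[C@@H]1c1cc(OC)c(OC)c(OC)c1` gives > 100000 nM (a limit)

These values come from a functional assay on HeLa cells (Homo sapiens) for cytotoxicity, read by MTT assay, with a stated time of 48 h; a higher number here means a weaker inhibitor, a lower number a stronger inhibitor. Compound 3 gives > 100000 nM as its reading, and this is a limit and not a number. Compound 1 also gives only a limit, > 100000 nM as its reading. For the measured compounds named here, compound 2 gives 28500 nM as its reading, the only true number in the set.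

The next compound, compound 4 `CCOC(=O)[C@]1(C(=O)Nc2ccccc2Cl)C[C@H]1c1cc(OC)c(OC)c(OC)c1`, is a close relative of compound 3. The change is the two compounds have the same atoms and bonds and differ only in configuration as drawn: 1 of 2 stereo elements differ; a stereocentre at a saturated ring carbon is drawn R in compound 3 and S in compound 4, so one stereocentre at a saturated ring carbon is drawn S instead of R.

Going by the values given here, the one measured step of this kind is a step that the two limits leave unreadable from compound 1 to compound 3, and it offers no size to carry over. The closest guide is the limit of > 100000 nM in this assay, at which 2 of the 3 values shown sit, together with the fact that compounds 1 and 3 differ only in the configuration as drawn. Neither gives a direction for the change.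

Among the compounds with values here, compound 4 is therefore expected to stay at or close to the same limit, with no step that can be firmly predicted. The estimated change is a number no higher from compound 3 to compound 4 (the limit leaves the size open) in this reading. For compound 4 the estimated value is 100000 nM, with an expected range from 35000 nM to 200000 nM.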

Compound 4, half-maximal inhibitory concentration: 42400 nM
Beside the measured number, compound 4's estimate is 2.4-fold (0.37 log units) above it; the measured number falls inside the stated range.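

Configuration at a single saturated ring carbon can bring a reading in this assay down from the limit of the assay, with an at least 2.3-fold lower number from compound 3 to compound 4 (0.37 log units; beyond the scatter), and nothing else in the structure changes: the fact that compounds 3 and 4 differ only in the configuration as drawn. Inverting both stereocentres gives an at least 2.3-fold lower number from compound 1 to compound 4 (0.37 log units; beyond the scatter), so the two mirror images are not equal in this assay, and this step, like the one before it, gives only a minimum size, as one end of each is a limit: the fact that compounds 1 and 4 differ only in the configuration as drawn. The step of a 1.5-fold higher number from compound 2 to compound 4 (0.17 log units; within the scatter) lies within the usual scatter, so with 2-chlorophenyl in place of 4-methylbenzyl on an amide-type nitrogen, these two readings cannot be told apart.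

From the compounds shown here alone, compounds 1 and 3 both rest at a limit, so the step between them cannot be read, and how far either lies from compound 4 remains unknown. Also open are whether the configuration matters in the same way with the 4-methylbenzyl amide, of which only one stereoisomer is shown, and whether a carboxylic acid in place of the ethyl ester would keep a reading of this size.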